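The source may hold more compounds than are shown below. What is called first, only, known or untested is meant among the compounds shown, and "the series" means these compounds.

Measured so far in a functional assay on the whole organism (strain CD1) with Mus musculus as the target, in the maximal electroshock model, with a stated time of 0.5 h; a higher number here means that more compound is needed for the effect, a lower number that less compound is needed:
compound 1 `Cc1ccccc1N1CCN(C(=O)CN2C(=O)CC(C)C2=O)CC1`, 300 mg/kg
compound 2 `CCC1(C)CC(=O)N(CC(=O)N2CCN(c3ccccc3C)CC2)C1=O`, 100 mg/kg
compound 3 `CCC1(C)CC(=O)N(CC(=O)N2CCN(c3cccc(C(F)(F)F)c3)CC2)C1=O`, 100 mg/kg

Compound 2 and compound 3 stand level at the digits given, within the scatter; how their two cores differ is not broken down here. Against compound 2, compound 1 carries hydrogen in place of ethyl on a saturated ring carbon, and this change made a 3.0-fold higher number from compound 2 to compound 1 (0.48 log units; beyond the scatter).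

Compound 4 `CC1CC(=O)N(CC(=O)N2CCN(c3cccc(C(F)(F)F)c3)CC2)C1=O` has not yet been measured in this assay. Going by the values given here, it arises from compound 3 by hydrogen in place of ethyl on a saturated ring carbon, the same change at the same place as the one from compound 2 to compound 1. A step of similar size is therefore expected, namely a 3.0-fold higher number from compound 3 to compound 4 (0.48 log units; beyond the scatter), resting on the step of a 3.0-fold higher number from compound 2 to compound 1 (0.48 log units; beyond the scatter). Compound 4 is estimated to give 300 mg/kg, with a range from 150 mg/kg to 600 mg/kg.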

Compound 4, minimum effective dose: 100 mg/kg
The estimate for compound 4 lay 3.0-fold (0.48 log units) above the measured number, outside the stated range (below it).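

In this assay, hydrogen in place of ethyl on a saturated ring carbon gave no change at the digits printed from compound 3 to compound 4 (within the scatter), so the change did not carry over at the size it had on the other core, and the two steps differ: the same change on two cores in this assay, a 3.0-fold higher number (0.48 log units; beyond the scatter) from compound 2 to compound 1 and no change at the digits printed (within the scatter) from compound 3 to compound 4, 3.0-fold (0.48 log units) apart, beyond the scatter of two such steps

For these two pairs, then, a step read on one core did not predict the step on the other. This does not show what in the two cores lies behind the difference, and two pairs give no rule for other cores.

The compounds shown leave open how a longer chain such as propyl, or a phenyl ring, would behave in place of ethyl on either core. Going by these compounds alone, they also leave open whether a third core, for instance one carrying a chloro group in place of trifluoromethyl, would show the step seen with compound 1 or the one seen with compound 4.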